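The source may hold more compounds than are shown below. What is called first, only, known or untested is meant among the compounds shown, and "the series" means these compounds.

Working notes on the thiazolo-fused series in an in vitro assay on cells for inhibition of Amine oxidase [flavin-containing] B (Homo sapiens), read by fluorescence and Amplex Red, with stated times of 30 min and 45 min; on this read-out higher numbers stand for weaker inhibition and lower numbers for stronger inhibition.

Compound 1 `Cc1sc2nc(NC(=O)CCCc3ccccc3)sc(=O)c2c1C`, with the dimethyl-substituted thiophene ring fused to the core and a four-carbon phenyl-bearing amide chain, gives 9.8 nM in this assay. Compound 2 `O=C(CCCc1ccccc1)Nc1nc2ccc(Cl)cc2c(=O)s1`, carrying the same amide chain on a benzene-fused core with a chloro substituent, is reported only as a limit of the assay, > 10000 nM, not as a number. Compound 3 `O=C(C/C=C/c1cccc(Cl)c1)Nc1nc2ccccc2c(=O)s1`, with an unsaturated chain and an unsubstituted benzene-fused core, is also reported only as a limit, > 1000 nM. Compound 2 therefore stands at the weak end of what is shown, with no number of its own; of the three values, one sits at the limit of > 1000 nM in this assay, at which 1 of the 3 values shown sits, and one at the limit of > 10000 nM in this assay, at which 1 of the 3 values shown sits.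

Compound 4 `O=C(CCCc1ccccc1)Nc1nc2ccc(Br)cc2c(=O)s1` differs from compound 2 by bromo in place of chloro on an aromatic carbon. Within the data shown here, no measured step of this kind is available. The step from compound 2 to compound 4 is expected to be a step that the limit leaves unreadable from compound 2 to compound 4, none beyond the scatter, because compound 2 gives > 10000 nM and the exchange of one halogen for another of the same size class gives no ground to expect a change of category. Compound 4 is therefore expected near 20000 nM, within 5000 nM to 80000 nM, and most likely to be reported again as a limit rather than a number.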

Compound 4, half-maximal inhibitory concentration: > 10000 nM
Compound 4: only a limit was reported; the forecaster's own chance of this, stated with the estimate: 85%; the middle value lies beyond the limit too.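

In this assay compound 4 gives > 10000 nM, a limit, and compound 2 is also reported only as a limit, so bromo in place of chloro on an aromatic carbon gives no readable step between compound 2 and compound 4. The compounds shown leave open how far either compound lies beyond its limit.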